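The source may report more compounds than this note shows. Statements on the series, on what has been measured and on what is new or still open speak of the compounds shown alone.

Measured in a functional assay on B16 cells (Mus musculus) for cytotoxicity, read by MTT assay, with a stated time of 3 days; a lower number here means a stronger inhibitor, a higher number a weaker inhibitor:
compound 1 `COc1ccc(C(=O)/C=C/c2ccccc2)cc1N` – reaches only the assay limit, > 100000 nM
compound 2 `COc1ccc(/C=C/C(=O)c2ccc(OC)c(N)c2)cc1` – 43000 nM
compound 3 `COc1cccc(/C=C/C(=O)c2ccc(OC)c(N)c2)c1` – 33000 nM

Compound 3 holds the lowest of the two numbers shown, but its distance from compound 2 is within the scatter, so no order between them is claimed. Compound 4 `COc1cc(/C=C/C(=O)c2ccc(OC)c(N)c2)cc(OC)c1` differs from compound 3 by methoxy in place of hydrogen on an aromatic carbon. On these data alone, two measured steps are of the same kind: an at least 2.3-fold lower number from compound 1 to compound 2 (0.36 log units; beyond the scatter) and an at least 3.0-fold lower number from compound 1 to compound 3 (0.48 log units; beyond the scatter), both at least modest and both starting from a limit (the limit of > 100000 nM in this assay, at which 1 of the 3 values shown sits), so their true size stays open. A further methoxy in place of hydrogen on an aromatic carbon is therefore expected to lower the number little, if at all: the step from compound 3 to compound 4 is estimated as a 1.7-fold lower number from compound 3 to compound 4 (0.22 log units; within the scatter), within the scatter. Compound 4 is expected at 20000 nM, with a range of 6000 nM to 60000 nM.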

Compound 4, half-maximal inhibitory concentration: 8800 nM
Beside the measured number, compound 4's estimate is 2.3-fold (0.36 log units) above it; the range from low to high includes it.
By their numbers in this assay, from the lowest: compound 4; then compounds 3 and 2 (each within the scatter of the next). At a limit, above all of these: compound 1.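

In this assay, a second methoxy on the ring, meta to a methoxy group, gives a 3.8-fold lower number from compound 3 to compound 4 (0.57 log units; beyond the scatter). Going by these compounds alone, this is the first step of this change with a real number at both ends, so its size can be read and the ring already carrying one methoxy still responds. Whether the step matches the earlier one stays unsettled: the same change on two cores in this assay, an at least 2.3-fold lower number (0.36 log units; beyond the scatter) from compound 1 to compound 2 and a 3.8-fold lower number (0.57 log units; beyond the scatter) from compound 3 to compound 4; the limit leaves it open whether they differ

On these data alone, what a hydroxyl, a chlorine atom or a longer ethoxy group would do at this place stays open. So does whether a third methoxy on the same ring would lower the number further.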